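A few compounds are considered here, and "the series" means these few. Any claim that something is new, unique, unknown or untested is made for them only; others in the source may bear on it.

Measured in an ADME assay on HEK293 cells (Homo sapiens) for cytotoxicity, read by resazurin assay, with a stated time of 48 h; on this read-out lower numbers stand for higher toxicity in this test and higher numbers for lower toxicity in this test:
- compound 1 `O=S(=O)(Nc1ccc2oc(-c3ccccc3)nc2c1)c1cccc(C(F)(F)F)c1`: > 100000 nM (a limit, not a number)
- compound 2 `O=S(=O)(Nc1ccc2oc(-c3ccccc3)nc2c1)c1ccc(Cl)cc1`: 65000 nM
- compound 3 `COc1ccc(S(=O)(=O)Nc2ccc3oc(-c4ccccc4)nc3c2)cc1`: 91000 nM

In this assay, compound 3 at 91000 nM lies within the scatter of compound 2 at 65000 nM, so these two numbers cannot be ranked. For compound 1 the reading is a limit: > 100000 nM.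

The next compound is compound 4 `Cc1cccc(S(=O)(=O)Nc2ccc3oc(-c4ccccc4)nc3c2)c1`, not yet measured. It has 3-methylphenyl in place of 4-methoxyphenyl on a sulfonyl sulfur. The shared core is untouched.

The closest measured precedent also changes the group on this sulfonyl sulfur: a 1.4-fold higher number from compound 2 to compound 3 (0.15 log units; within the scatter). Within the data shown here, that step stays within the scatter, and it is the only measured step between two numbers. The upper end of the scale also matters here: the limit of > 100000 nM in this assay, at which 1 of the 3 values shown sits. On this basis, no step beyond the scatter is expected in this assay, in either direction. The expected step is small: a 1.0-fold lower number from compound 3 to compound 4 (0.00 log units; within the scatter). Compound 4 is estimated at 90000 nM. The expected range for compound 4 runs from 55000 nM to 140000 nM, and a reading that is only a limit remains possible.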

Compound 4, half-maximal cytotoxic concentration: 69000 nM
For compound 4 the middle estimate is 1.3-fold (0.12 log units) above the measured one; measured number inside the range.
By their numbers in this assay, from the lowest: compounds 2, 4 and 3 (each within the scatter of the next). At a limit, above all of these: compound 1.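

In this assay, the sulfonyl sulfur now carries a third aromatic group with a measured number: 3-methylphenyl in place of 4-methoxyphenyl gives a 1.3-fold lower number from compound 3 to compound 4 (0.12 log units; within the scatter), and 3-methylphenyl in place of 4-chlorophenyl gives a 1.1-fold higher number from compound 2 to compound 4 (0.03 log units; within the scatter). Among these compounds, the single earlier step between two numbers is therefore no longer alone, and compound 2, compound 3 and compound 4 form a flat group at this position, none of them separable from the others. The remaining step, an at least 1.4-fold lower number from compound 1 to compound 4 (0.16 log units; that floor lies within the scatter), starts from a limit and gives only a floor, so it neither joins nor breaks this flat group, and the top of the scale stays in view: the limit of > 100000 nM in this assay, at which 1 of the 4 values shown sits.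

The compounds shown carry only substituted phenyl groups on this sulfonyl sulfur, so the outcome in this assay for an amine or a carboxylic acid on that ring, or for a saturated ring in its place, remains open. Changes elsewhere on the shared core are also open, as is whether any group at this position can move the number beyond the scatter.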